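Anilino-pyrimidine series: from compound 3 to compound 4

This account rests on a few compounds, and the source may have more. Where it says the series, first, only, none or still open, it means among the compounds named here.

Measured compounds:
- compound 1, `Cc1ccccc1Nc1nc(NCc2ccccc2)ncc1Cl`: > 100000 nM
- compound 2, `CN1CCN(c2ccc(Nc3ncc(Cl)c(NCc4ccc(F)cc4)n3)nc2)CC1`: > 100000 nM
- compound 3, `COc1cccc(CNc2nc(Nc3ccc(N4CCN(C)CC4)cn3)ncc2Cl)c1`: 20300 nM

In a functional assay on MDA-MB-231 cells (Homo sapiens) for inhibition, read by CCK-8 assay, with a stated time of 48 h (a higher number here means a weaker inhibitor of growth, a lower number a stronger inhibitor of growth), compound 1 gives > 100000 nM, which is a limit of the assay and not a number. Compound 2 likewise gives > 100000 nM, again a limit. For the measured compounds named here, compound 3 is the only compound with a number, 20300 nM; the step of an at least 4.9-fold lower number from compound 2 to compound 3 (0.69 log units; beyond the scatter) is the one measured step, and it goes beyond the scatter, which shows that the group on the saturated chain carbon bound to the nitrogen on the aromatic ring can move the number (the limit of > 100000 nM in this assay, at which 2 of the 3 values shown sit).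

The next compound is compound 4, `CN1CCN(c2ccc(Nc3ncc(Cl)c(Nc4ccc(C(C)(C)C)cc4)n3)nc2)CC1`. It differs from compound 3 by 4-(tert-butyl)phenyl in place of 3-methoxybenzyl on a nitrogen on an aromatic ring. Going by the values given here, no measured step covers an aryl group placed directly on that nitrogen, so the measured step to compound 3 bears on it only loosely: the 3-methoxybenzyl that leaves is the group that brought compound 3 off the limit, and the entering group carries no methoxy. A step back toward the limit is therefore expected, though its size is uncertain.

Compound 4 is estimated at 50000 nM (range 10000 nM to 150000 nM), an expected step of a 2.5-fold higher number from compound 3 to compound 4 (0.39 log units; beyond the scatter).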

Compound 4, concentration for 50% growth inhibition: 16200 nM
Beside the measured number, compound 4's estimate is 3.1-fold (0.49 log units) above it; low and high end bracket the measured number.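

In this assay the change reads as a 1.3-fold lower number from compound 3 to compound 4 (0.10 log units; within the scatter), which lies within the scatter, so a 4-(tert-butyl)phenyl on the nitrogen on an aromatic ring serves as well as the 3-methoxybenzyl, and the methoxy group is not required for a measurable number. Compound 2 gives > 100000 nM, which is a limit of the assay and not a number. The step of an at least 6.1-fold lower number from compound 2 to compound 4 (0.79 log units; beyond the scatter) therefore has only a lower bound on its size, but it gives a second case, after compound 3, in which replacing the 4-fluorobenzyl of compound 2 moves the read-out off the limit: the limit of > 100000 nM in this assay, at which 2 of the 4 values shown sit.

The compounds shown leave open how much of this result belongs to the tert-butyl and how much to an aryl group sitting directly on the nitrogen, since the two differ together from compound 3 to compound 4. An unsubstituted phenyl, or a phenyl carrying a carboxylic acid or a dimethylamino group, would separate these, and nothing here shows whether any group at this place can go well beyond the level shared by compound 3 and compound 4.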